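Compound 2 to compound 3: one amide substituent changes

The compounds below may be only part of what the source reports. "The series", "measured", "known", "first", "only" and "open" are said of these compounds alone.

In an ADME assay on a cell-free system (plasma, Homo sapiens) for metabolic stability, tested at 1 uM (on this read-out lower numbers stand for a shorter-lived compound and higher numbers for a longer-lived compound), compound 1 `C=CC(=O)NC1CCN(S(=O)(=O)c2ccc(C(=O)N[C@@H]3C[C@H]3c3ccccc3)cc2)CC1` gives > 6 h, which is a limit of the assay. Compound 2 `C=CC(=O)NC1CCN(S(=O)(=O)c2ccc(C(=O)NCc3cccc4ccccc34)cc2)CC1` gives > 6 h, also a limit and not a number. Among the measured compounds shown here, these two compounds form the only measured comparison, a step that the two limits leave unreadable from compound 1 to compound 2, and the limit of > 6 h in this assay, at which 2 of the 2 values shown sit, holds both. Compound 3 `C=CC(=O)NC1CCN(S(=O)(=O)c2ccc(C(=O)NC3CCCc4ccccc43)cc2)CC1` carries 1,2,3,4-tetrahydronaphthalen-1-yl in place of (naphthalen-1-yl)methyl on an amide-type nitrogen. With the size of the step from compound 1 to compound 2 unreadable, no clear direction can be drawn, and the expected change is a step that the limit leaves unreadable from compound 2 to compound 3, none beyond the scatter. Compound 3 is expected near 8 h, with an estimated range of 4 h to 16 h.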

Compound 3, half-life: > 6 h
Compound 3: only a limit was reported; the forecaster's own chance of this, stated with the estimate: 75%; the middle value does not contradict the limit.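

Compound 3 gives > 6 h, a limit and not a number, so its steps from compound 1 and from compound 2 cannot be read. How far the half-lives of the three compounds differ stays open: the limit of > 6 h in this assay, at which 3 of the 3 values shown sit.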